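Replacing the 4-(dimethylamino)phenyl group of compound 2

The source may report more compounds than this note shows. Statements on the series, on what has been measured and on what is new or still open speak of the compounds shown alone.

In a functional assay on COLO 205 cells (Homo sapiens) for inhibition, read by sulforhodamine B assay (a higher number here means a weaker inhibitor of growth, a lower number a stronger inhibitor of growth), compound 1 (`c1ccc(-c2ccc(-c3ccc(-c4nc5ccccc5[nH]4)cc3)cc2)cc1`) gives 100000 nM and compound 2 (`Cc1ccc2[nH]c(-c3ccc(-c4ccc(-c5ccc(N(C)C)cc5)cc4)cc3)nc2c1`) gives 9210 nM as its read-out. Among the compounds with values here, compound 2 thus holds the lower of the only two numbers so far and is the stronger growth inhibitor of the pair. Compound 3 (`Cc1ccc2[nH]c(-c3ccc(-c4ccc(-c5cccc(Cl)c5)cc4)cc3)nc2c1`) has not yet been measured. It carries 3-chlorophenyl in place of 4-(dimethylamino)phenyl on an aromatic carbon, para to a large group (3-chlorophenyl in place of 4-(dimethylamino)phenyl on an aromatic carbon). Within the data shown here, no measured pair isolates this change, so the data give no direct size for it. Among the measured compounds shown here, the only higher reference is compound 1 at 100000 nM and so a shift in that direction is expected in this assay with some caution. The expected move is a 3.3-fold higher number from compound 2 to compound 3 (0.51 log units; beyond the scatter) toward weaker inhibition, beyond the scatter. For compound 3 the estimated value is 30000 nM with an expected range from 9000 nM to 100000 nM in this measurement.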

Compound 3, concentration for 50% growth inhibition: 2780 nM
Compound 3: the middle estimate sits 11-fold (1.03 log units) above what was measured; measured number below the stated range.
By their numbers in this assay, from the lowest: compound 3; then compound 2; then compound 1.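

In this assay, putting 3-chlorophenyl in place of 4-(dimethylamino)phenyl on this aromatic carbon, para to a large group, gives a 3.3-fold lower number from compound 2 to compound 3 (0.52 log units; beyond the scatter), a modest strengthening of growth inhibition that lies beyond the scatter. This first measured step at the position shows that the dimethylamino group is not required for the growth inhibition seen with compound 2, and that this site accepts an exchange of one substituted phenyl group for another without loss of inhibition. No measurement at hand accounts for the size or direction of this step. Because the substituent and its place on the phenyl ring change together, the compounds shown do not separate the two effects. Plain phenyl, 4-chlorophenyl and 3-(dimethylamino)phenyl would each bear on that question, and a carboxylic acid on the same ring remains open as well.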